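A Thiophene Swap on an Inactive Nucleoside

This account rests on a few compounds, and the source may have more. Where it says the series, first, only, none or still open, it means among the compounds named here.

Compound 1 `Nc1nc(N)c2c(-c3cccs3)cn([C@@H]3O[C@H](CO)[C@@H](O)[C@H]3O)c2n1` gives > 20000 nM (a limit)
Compound 2 `COc1nc(N)nc2c1c(-c1ccoc1)cn2[C@@H]1O[C@H](CO)[C@@H](O)[C@H]1O` gives > 20000 nM (a limit)

Both readings come from a functional assay on K562 cells (Homo sapiens), read by MTT assay, with a stated time of 72 h; on this read-out higher numbers stand for weaker inhibition and lower numbers for stronger inhibition. Neither is a true number, so each shows only that the half-maximal concentration was not reached. Compound 2 therefore has no exact position, and it shares its place with compound 1 at the limit of > 20000 nM in this assay, at which 2 of the 2 values shown sit.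

The next compound, compound 3 `COc1nc(N)nc2c1c(-c1cccs1)cn2[C@@H]1O[C@H](CO)[C@@H](O)[C@H]1O`, keeps the core of compound 2 and changes one group on an aromatic carbon of a five-membered aromatic ring with 1 nitrogen, thiophen-2-yl in place of furan-3-yl on an aromatic carbon. The two groups have the same counted size, and the swap leaves the rest of the molecule untouched.

Among the compounds with values here, no measured step between two compounds is available as a guide. Compound 1 also carries thiophen-2-yl, and compound 1 gives > 20000 nM, which is a limit. In this assay no step beyond the scatter is expected, in either direction. The expected step is a number no higher from compound 2 to compound 3 (the limit leaves the size open). For compound 3 the estimate is 20000 nM, with an expected range from 8000 nM to 40000 nM.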

Compound 3, half-maximal inhibitory concentration: > 20000 nM
Compound 3 gave a limit, no number; the forecaster's own chance of this, stated with the estimate: 80%; the middle value lies on the limit itself.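

Compound 3 also ends at a limit, so neither its comparison with compound 2 nor its comparison with compound 1 gives a step that can be read: the limit of > 20000 nM in this assay, at which 3 of the 3 values shown sit. The compounds shown leave open how strongly each of the three inhibits, and whether either single change, thiophen-2-yl for furan-3-yl or methoxy for amino, alters that inhibition at all.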